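This account rests on a few compounds, and the source may have more. Where it says the series, first, only, none or still open, it means among the compounds named here.

Measured in a functional assay on MDA-MB-231 cells (Homo sapiens) for antiproliferative activity, read by MTT assay, with a stated time of 24 h; on this read-out higher numbers stand for weaker inhibition and lower numbers for stronger inhibition:
- compound 1 `Cc1cccc(NNC(=O)c2cccc(NS(=O)(=O)c3cnc(O)nc3O)c2)c1`: > 20000 nM
- compound 2 `Cc1ccccc1NNC(=O)c1ccccc1NS(=O)(=O)c1cnc(O)nc1O`: > 20000 nM
- compound 3 `O=C(NNc1ccc(F)cc1)c1ccccc1NS(=O)(=O)c1cnc(O)nc1O`: > 20000 nM

Compound 1 stands at > 20000 nM, which is a limit and not a number. The readings for compound 2 and compound 3 are limits of the same kind, so compound 1 cannot be ranked against either. The whole measured set comes down to the limit of > 20000 nM in this assay, at which 3 of the 3 values shown sit.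

Compound 4 `Cc1ccccc1C(=O)NNC(=O)c1cccc(NS(=O)(=O)c2cnc(O)nc2O)c1` has not yet been measured. Its difference from compound 1 is (2-methylphenyl)carbonyl in place of 3-methylphenyl on an amine nitrogen. Put simply, (2-methylphenyl)carbonyl comes in place of 3-methylphenyl on an amine nitrogen.

Going by the values given here, the one measured step that bears on this is a step that the two limits leave unreadable from compound 2 to compound 3, which also exchanges the group on an amine nitrogen. It offers no size to carry over, so no step beyond the scatter can be forecast in this assay, in either direction. The expectation rests on compound 1, whose > 20000 nM is a limit. The expected step is a step that the limit leaves unreadable from compound 1 to compound 4, and it remains an estimate with no firm direction. For compound 4 the estimated value is 25000 nM, with an expected range of 8000 nM to 60000 nM.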

Compound 4, half-maximal inhibitory concentration: 18100 nM
Estimate against measurement, compound 4: 1.4-fold (0.14 log units) above, and the stated range covers the measured number.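

In this assay compound 4 gives 18100 nM, the only value in the set that is a number and not a limit: the limit of > 20000 nM in this assay, at which 3 of the 4 values shown sit.

Compound 1 stays at > 20000 nM, which is a limit. Setting (2-methylphenyl)carbonyl in place of 3-methylphenyl on an amine nitrogen gives an at least 1.1-fold lower number from compound 1 to compound 4 (0.04 log units; that floor lies within the scatter), so this position tolerates a larger group carrying a carbonyl and can yield a readable number, but the data show no gain beyond the scatter.

On these data alone, the true size of that step stays open, as compound 1 has no number to set against it, and the other steps in the set cannot be read either. As far as these compounds go, it also remains open whether an amine, a carboxylic acid or a longer chain on that same nitrogen would move the reading beyond the scatter in this assay.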